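The compounds below may be only part of what the source reports. "The series", "measured", "known", "first", "only" and "open" are said of these compounds alone.

Measured so far in an ADME assay on MDBK cells (Bos taurus) for cytotoxicity; a higher number here means that more compound is tolerated, a lower number that less compound is tolerated:
- Compound 1 `COc1ccccc1Cn1ccc2nc(-c3ccccc3)nc-2c1`: > 100000 nM (a limit)
- Compound 2 `CC(C)CCn1ccc2nc(-c3ccccc3)nc-2c1`: > 100000 nM (a limit)
- Compound 3 `C(=C/c1ccccc1)\Cn1ccc2nc(-c3ccccc3)nc-2c1`: 78000 nM

Going by the values given here, compound 3 holds the only true number of the three, while the other two values are the limit of > 100000 nM in this assay, at which 2 of the 3 values shown sit.

Compound 4 `c1ccc(-c2nc3ccn(Cc4cccnc4)cc-3n2)cc1` carries pyridin-3-yl in place of 2-phenylethenyl on a saturated chain carbon bound to an aromatic nitrogen.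

Two measured steps changed this same group, an at least 1.2-fold lower number from compound 1 to compound 3 (0.10 log units; that floor lies within the scatter) and an at least 1.2-fold lower number from compound 2 to compound 3 (0.10 log units; that floor lies within the scatter). Both are floors within the scatter. The third, a step that the two limits leave unreadable from compound 1 to compound 2, cannot be read. Nothing here therefore points to a large change in this assay, and no step beyond the scatter is expected.

The expected step is a 1.2-fold higher number from compound 3 to compound 4 (0.06 log units; within the scatter).

For compound 4 the estimated value is 90000 nM, with an expected range of 45000 nM to 160000 nM.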

Compound 4, half-maximal cytotoxic concentration: > 100000 nM
Compound 4: no number, only a limit; the forecaster's own chance of this, stated with the estimate: 55%; middle value at least 1.1-fold (0.04 log units) from the limit.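

In this assay, compound 4 gives > 100000 nM, which is a limit and not a number. Going by these compounds alone, this is the first ring with a hetero atom at this place, and it gives an at least 1.2-fold higher number from compound 3 to compound 4 (0.10 log units; that floor lies within the scatter), so the nitrogen of pyridin-3-yl brings no readable change. The steps to compound 4 from compound 1 and compound 2 cannot be read because both ends of each are limits: the limit of > 100000 nM in this assay, at which 3 of the 4 values shown sit.

The compounds shown leave open whether any group on this chain carbon moves the number beyond the scatter. An amine or a carboxylic acid here remains an open case in this assay.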